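This account rests on a few compounds, and the source may have more. Where it says the series, first, only, none or still open, it means among the compounds named here.

Compound 1, `C=C[C@@](C)(/C=C/c1ccc(OCc2ccccc2)cc1)CCC=C(C)C`, was examined in a functional assay on Raji cells (Homo sapiens) for cytotoxicity, with a stated time of 72 h; a higher number here means that more compound is needed for the effect, a lower number that less compound is needed. In this assay compound 1 gives > 26000 nM, which is a limit of the assay rather than a number. Compound 2, `C=C[C@@](C)(/C=C/c1ccc(O)cc1)CC/C=C(\C)C(=O)OCC`, gives > 26000 nM, again a limit. Compound 3, `C=C[C@@](C)(/C=C/c1ccc(O)cc1)CC/C=C(C)/C=C/C(=O)OCc1ccccc1`, gives > 26000 nM, also a limit. Going by the values given here, compound 1 therefore stands no differently from the other two measured compounds: all of them sit at the limit of > 26000 nM in this assay, at which 3 of the 3 values shown sit, and no measured step between any pair of them is known.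

Compound 4, `C=C[C@@](C)(/C=C/c1ccc(-c2ccc(F)cc2)cc1)CCC=C(C)C`, has not yet been measured in this assay. It differs from compound 1 in one place (4-fluorophenyl in place of benzyloxy on an aromatic carbon). Among the compounds with values here, since every measured compound sits at the limit, the measured compounds offer no step from which to gauge the size or direction of this change. The step expected from compound 1 to compound 4 is a step that the limit leaves unreadable from compound 1 to compound 4, that is, nothing beyond the scatter. Compound 4 is expected to give about 30000 nM in this assay, with a range from 8000 nM to 120000 nM, and most probably only a limit once more.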

Compound 4, half-maximal effective concentration: > 26000 nM
Compound 4 gave a limit, no number; the forecaster's own chance of this, stated with the estimate: 70%; the middle value lies beyond the limit too.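

No step from compound 1 to compound 4 can be read in this assay because both give only a limit of the assay, like every compound shown: the limit of > 26000 nM in this assay, at which 4 of the 4 values shown sit.

The compounds shown leave open whether 4-fluorophenyl in place of benzyloxy changes cytotoxicity at all, and what structural change would bring a readable number.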